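Methoxy in place of fluoro: a small expected change

The compounds below may be only part of what the source reports. "The series", "measured", "known", "first", "only" and "open" are said of these compounds alone.

Compound 1 `Cn1nnnc1SCC(=O)N/N=C/c1ccccc1`, compound 2 `Cn1nnnc1SCC(=O)N/N=C/c1cccc(F)c1` and compound 3 `Cn1nnnc1SCC(=O)N/N=C/c1ccccc1Cl` share one core and differ only on the benzene ring. In an ADME assay on NIH3T3 cells (Mus musculus) for cytotoxicity, read by XTT assay, with a stated time of 24 h (a lower number here means a stronger inhibitor, a higher number a weaker inhibitor), compound 1 gives 9700000 nM and compound 2 gives 6320000 nM. Compound 3 reaches only a limit of the assay, > 10000000 nM. The step of a 1.5-fold lower number from compound 1 to compound 2 (0.19 log units; within the scatter) and the step of an at least 1.0-fold higher number from compound 1 to compound 3 (0.01 log units; that floor lies within the scatter) both stay within the scatter. Compound 2 holds the lower of the two plain numbers, but it cannot be told apart from compound 1. Compound 4 `COc1cccc(/C=N/NC(=O)CSc2nnnn2C)c1` differs from compound 2 by methoxy in place of fluoro on an aromatic carbon. Because the nearest measured change, a 1.5-fold lower number from compound 1 to compound 2 (0.19 log units; within the scatter), stayed within the scatter, no step beyond the scatter is expected for compound 4 in this assay, and the expected step is a 1.1-fold higher number from compound 2 to compound 4 (0.04 log units; within the scatter). Compound 4 is estimated at 7000000 nM, between 3500000 nM and 14000000 nM.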

Compound 4, half-maximal inhibitory concentration: 600000 nM
Compound 4: middle estimate off by 12-fold (1.07 log units), on the high side; measured number outside the range, below it.
By their numbers in this assay, from the lowest: compound 4; then compounds 2 and 1 (each within the scatter of the next). At a limit, above all of these: compound 3.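

At this position on the ring, fluoro stayed within the scatter of the unsubstituted compound 1, which gave no sign that a group here could matter. Methoxy on the same aromatic carbon changes that in this assay with an 11-fold lower number from compound 2 to compound 4 (1.02 log units; beyond the scatter) and with a 16-fold lower number from compound 1 to compound 4 (1.21 log units; beyond the scatter) as the first steps here beyond the scatter. The position therefore responds to at least one group.

Going by these compounds, whether ethoxy or an amine on this carbon would go further remains open. Nothing shown explains the step.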